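Swapping a Seven-Membered Ring for a Methylphenyl Group

The compounds below may be only part of what the source reports. "The series", "measured", "known", "first", "only" and "open" are said of these compounds alone.

Compound 1 `CC(C)C[C@H](N)CN(C(=O)[C@@H]1C[C@H]1c1ccccc1)c1ccc(-c2cccs2)cc1`: 1500 nM
Compound 2 `CC(C)C[C@H](N)CN(C(=O)[C@@H]1C[C@H]1c1ccccc1)c1ccc(C2=CCCCCC2)cc1`: 2100 nM

Both compounds were tested in a functional assay for agonist activity at G protein-coupled receptor 88 (Homo sapiens), read by HTRF and cAMP accumulation; a higher number here means that more compound is needed for the effect, a lower number that less compound is needed. Among the measured compounds shown here, compound 2 has the highest number of the two, but its only neighbour, compound 1, lies close: the step of a 1.4-fold higher number from compound 1 to compound 2 (0.15 log units; within the scatter) is within the usual scatter, so the two compounds cannot be told apart on these numbers.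

Compound 3 `Cc1cccc(-c2ccc(N(C[C@@H](N)CC(C)C)C(=O)[C@@H]3C[C@H]3c3ccccc3)cc2)c1` is the next compound. It differs from compound 2 in one place: 3-methylphenyl in place of cyclohept-1-en-1-yl on an aromatic carbon. For the measured compounds named here, only one measured step bears on this change, the one from compound 1 to compound 2, which also replaced the group at this same position on the aromatic carbon and stayed within the scatter (a 1.4-fold higher number from compound 1 to compound 2 (0.15 log units; within the scatter)). Going by the values given here, with one such step as the only guide, the new group is expected to make little difference, and the step from compound 2 to compound 3 in this assay is estimated as a 1.3-fold lower number from compound 2 to compound 3 (0.12 log units; within the scatter). For compound 3 the estimated value is 1600 nM, with a range from 600 nM to 4500 nM.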

Compound 3, half-maximal effective concentration: 1200 nM
Compound 3: middle estimate off by 1.3-fold (0.12 log units), on the high side; low and high end bracket the measured number.
By their numbers in this assay, from the lowest: compounds 3, 1 and 2 (each within the scatter of the next).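

In this assay, the position on an aromatic carbon, para to a large group, has now carried three different rings, and the numbers do not separate them: the steps of a 1.8-fold lower number from compound 2 to compound 3 (0.24 log units; within the scatter) and a 1.3-fold lower number from compound 1 to compound 3 (0.10 log units; within the scatter) both stay within the scatter. The new information lies in the kind of ring. 3-Methylphenyl has a six-membered aromatic ring of carbon only, while cyclohept-1-en-1-yl has a seven-membered non-aromatic ring, and the two groups have the same heavy-atom count, yet compound 3 cannot be told apart from compound 2, so among these three compounds neither ring size nor aromatic character shows up in the number. Nothing available explains why these groups give such similar numbers.

From the compounds shown here alone, all three groups are rings without a charge, so it remains open whether a primary amine or a carboxylic acid at this position would keep the number in the same range. It is also open whether a much smaller group, such as a single fluorine or a methoxy, or a plain phenyl without the methyl, would fall within the scatter of these compounds or clearly outside it.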